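Replacing 2,5-dimethoxyphenyl with phenyl in compound 1

This account rests on a few compounds, and the source may have more. Where it says the series, first, only, none or still open, it means among the compounds named here.

Compound 1 `COc1ccc(OC)c(C2=C(c3cc(OC)c(OC)c(OC)c3)C(=O)CC2O[SiH2]C(C)(C)C)c1`: 9.5 ug/mL
Compound 2 `COc1ccc(C2=C(c3cc(OC)c(OC)c(OC)c3)C(=O)C(OC(C)=O)C2)cc1F`: 59 ug/mL
Compound 3 `COc1ccc(C2=C(c3cc(OC)c(OC)c(OC)c3)C(=O)C(O)C2)cc1Cl`: > 100 ug/mL

In an ADME assay on HEK293 cells (Homo sapiens) for cytotoxicity, read by MTT assay, with a stated time of 72 h (a lower number here means a stronger inhibitor, a higher number a weaker inhibitor), compound 1 gives 9.5 ug/mL, the lower of the two actual numbers. Compound 2 gives 59 ug/mL. The gap between these two compounds lies beyond the scatter. Compound 3 has only a limit of the assay, > 100 ug/mL.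

Compound 4 `COc1cc(C2=C(c3ccccc3)C(O[SiH2]C(C)(C)C)CC2=O)cc(OC)c1OC` has not yet been measured. It carries phenyl in place of 2,5-dimethoxyphenyl on a double-bonded ring carbon. For the measured compounds named here, no measured pair shows this change, so the expectation starts from compound 1 alone. The expected step is a 1.5-fold higher number from compound 1 to compound 4 (0.17 log units; within the scatter), small, towards a higher number and not clearly beyond the scatter in this assay. Compound 4 is estimated at 14 ug/mL, with an expected range from 5 ug/mL to 40 ug/mL.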

Compound 4, half-maximal inhibitory concentration: > 100 ug/mL
Compound 4 was reported as a limit; the forecaster's own chance of this, stated with the estimate: 5%; middle value at least 7.1-fold (0.85 log units) from the limit.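

In this assay, for the compounds shown here, phenyl in place of 2,5-dimethoxyphenyl on a double-bonded ring carbon gives an at least 10-fold higher number from compound 1 to compound 4 (1.02 log units; beyond the scatter), the first step at this position in which only one place differs. Going by these compounds alone, the cytotoxicity of compound 1 therefore depends on the 2,5-dimethoxyphenyl group, which the earlier compounds could not show. Compound 4 gives > 100 ug/mL, which is a limit of the assay and not a number, so the step shows only the least size of the change: the limit of > 100 ug/mL in this assay, at which 2 of the 4 values shown sit.

Going by these compounds, whether a single methoxy on the phenyl would keep the number of compound 1 remains open. So does the effect of an amine on that ring.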